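The source may report more compounds than this note shows. Statements on the series, on what has been measured and on what is new or still open speak of the compounds shown alone.

In a functional assay on CHO cells for agonist activity at Alpha-1B adrenergic receptor (Homo sapiens), read by FLIPR and calcium flux (on this read-out lower numbers stand for an effect already at smaller amounts and higher numbers for an effect only at larger amounts of compound), compound 3, with the structure `c1ccc(-c2cccc3c2CCC3c2ncc[nH]2)nc1`, gives only a limit of the assay, > 10000 nM, and not a number. Compound 1, `CS(=O)(=O)Nc1cccc2c1CCC2c1ncc[nH]1`, likewise gives in this assay only a limit, > 10000 nM. Compound 2, `Cc1oncc1-c1cccc2c1CCC2c1ncc[nH]1`, also reaches in this assay only a limit, > 10000 nM. Because all three values sit at the limit of > 10000 nM in this assay, at which 3 of the 3 values shown sit, none of the three compounds can be set apart from the others on the numbers shown, and compound 3 cannot be placed higher or lower than compound 1 or compound 2.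

The change that leads to compound 4, `Cc1n[nH]cc1-c1cccc2c1CCC2c1ncc[nH]1`, is 3-methyl-1H-pyrazol-4-yl in place of pyridin-2-yl on an aromatic carbon. Three measured steps on this shared core, each swapping the group on an aromatic carbon, bear on it: a step that the two limits leave unreadable from compound 1 to compound 3, a step that the two limits leave unreadable from compound 2 to compound 3 and a step that the two limits leave unreadable from compound 1 to compound 2. Each of these steps joins two limits, so none has a readable size, and none shows that exchanging one small aromatic group for another on that aromatic carbon brings the read-out into the measurable range. The step that this estimate implies is expected to be a number no higher from compound 3 to compound 4 (the limit leaves the size open), with no direction the data can support. Compound 4 is estimated at 10000 nM in this assay, within a range from 3000 nM to 30000 nM, and is most likely to be reported again only as a limit.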

Compound 4, half-maximal effective concentration: 902 nM
For compound 4 the middle estimate is 11-fold (1.04 log units) above the measured one; measured number outside the range, below it.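

Replacing pyridin-2-yl with 3-methyl-1H-pyrazol-4-yl on this aromatic carbon brings the read-out in this assay into the measurable range, with an at least 11-fold lower number from compound 3 to compound 4 (1.04 log units; beyond the scatter), even though the two groups have the same count of heavy atoms. The same group also gives an at least 11-fold lower number from compound 2 to compound 4 (1.04 log units; beyond the scatter) where it replaces 5-methyl-1,2-oxazol-4-yl, and an at least 11-fold lower number from compound 1 to compound 4 (1.04 log units; beyond the scatter) where it replaces methanesulfonamido, so this position on the shared core can carry a group that gives a measurable effect. Each of these sizes is only a minimum, because compound 1, compound 2 and compound 3 each give a limit of the assay and not a number: the limit of > 10000 nM in this assay, at which 3 of the 4 values shown sit.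

With only one number at this position, the compounds shown do not tell which feature of the 3-methyl-1H-pyrazol-4-yl group goes with the lower number: its five-membered ring, its hydrogen-bond donor or its methyl. On these data alone, how an amine, a carboxylic acid or a pyrazol-4-yl group without the methyl would read on this aromatic carbon also remains open.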